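The source may report more compounds than this note shows. Statements on the series, on what has been measured and on what is new or still open speak of the compounds shown alone.

Measured so far:
Compound 1, `O=C1CC(c2ccccc2OCc2ccc(F)cc2)Oc2ccccc21`, 28200 nM
Compound 2, `CCCCOc1ccccc1C1CC(=O)c2ccccc2O1`, 48700 nM

Among the compounds with values here, in a functional assay on RAW264.7 cells (Mus musculus) for inhibition, read by Griess assay, with stated times of 1 h and 24 h (a lower number here means a stronger inhibitor, a higher number a weaker inhibitor), compound 1 gives the lowest of the two numbers known, and its nearest neighbour is compound 2, separated by a 1.7-fold higher number from compound 1 to compound 2 (0.24 log units; within the scatter), so the two cannot be ordered. Compound 3, `COCOc1ccccc1C1CC(=O)c2ccccc2O1`, has not yet been measured. It differs from compound 1 by methoxy in place of 4-fluorophenyl on a saturated chain carbon bound to an oxygen on an aromatic ring. Within the data shown here, only one measured step bears on this change: the step at the same place, with propyl in place of 4-fluorophenyl, gave a 1.7-fold higher number from compound 1 to compound 2 (0.24 log units; within the scatter). That replacement of the 4-fluorophenyl with a small chain left the number essentially unchanged, so for the methoxy replacement compound 3 is expected to stay close to compound 1, with at most a drift toward a higher number. The step expected is a 1.4-fold higher number from compound 1 to compound 3 (0.15 log units; within the scatter). Compound 3 is therefore estimated at 40000 nM in this assay, with a range from 15000 nM to 110000 nM.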

Compound 3, half-maximal inhibitory concentration: 32600 nM
Compound 3: the middle estimate sits 1.2-fold (0.09 log units) above what was measured; measured number inside the range.
By their numbers in this assay, from the lowest: compounds 1, 3 and 2 (each within the scatter of the next).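

In this assay, methoxy in place of 4-fluorophenyl gives a 1.2-fold higher number from compound 1 to compound 3 (0.06 log units; within the scatter) and methoxy in place of propyl gives a 1.5-fold lower number from compound 2 to compound 3 (0.17 log units; within the scatter) so the three groups at this place, on a saturated chain carbon bound to an oxygen on an aromatic ring, cannot be told apart. The earlier pair showed this for a chain alone, whereas compound 3 extends it to methoxy, which brings in a hydrogen-bond acceptor and has no ring. No measurement shown here offers an explanation for these results.

Going by these compounds, whether an amine, a carboxylic acid or a longer chain at this place would give a step beyond the scatter remains open. Also open, on these data alone, is whether changes to the shared core would matter more than changes to this group, as all three compounds carry the same core.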